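A few compounds are considered here, and "the series" means these few. Any claim that something is new, unique, unknown or untested is made for them only; others in the source may bear on it.

Working notes on the aminothiophene series.

The three measured compounds share one core and differ only in the group on an amine nitrogen in a ring. Compound 1 `Nc1scc(CN2CCN(c3cccc(Cl)c3Cl)CC2)c1C(=O)c1ccc(Cl)cc1` gives 3.2% in a functional assay on CHO cells with adenosine receptor A1 (Homo sapiens) as the target, read by cAMP accumulation and immunoassay, with a stated time of 6 min, tested at 0.1 uM; a lower number here means a stronger effect, a higher number a weaker effect of the compound at the concentration tested. Compound 2 `Nc1scc(CN2CCN(C3CCCCCC3)CC2)c1C(=O)c1ccc(Cl)cc1` gives 13% in this assay, and compound 3 `Nc1scc(CN2CCN(c3cccc(F)c3)CC2)c1C(=O)c1ccc(Cl)cc1` gives -37%, the lowest of the three numbers; the gap to compound 1 and to compound 2 is beyond the scatter in both cases, the gap between compound 1 and compound 2 is not.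

Compound 4 `Nc1scc(CN2CCN(c3c(F)cccc3F)CC2)c1C(=O)c1ccc(Cl)cc1` is not yet measured. The change from compound 3 is 2,6-difluorophenyl in place of 3-fluorophenyl on an amine nitrogen in a ring.

Going by the values given here, the steps that bear on it are those into compound 3: a number 40.2 percentage points lower from compound 1 to compound 3 (beyond the scatter) and a number 50 percentage points lower from compound 2 to compound 3 (beyond the scatter). Both show that changing the group on this nitrogen can move this read-out by a large amount, but neither involves 2,6-difluorophenyl, so the direction for compound 4 is open. Since compound 1 with 2,3-dichlorophenyl sits at 3.2%, a move back upward is taken as somewhat more likely than a further fall; the expected step is a number 27 percentage points higher from compound 3 to compound 4 (beyond the scatter).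

Compound 4 is estimated at -10%, with a range from -40% to 20%.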

Compound 4, a percentage reported as activity, at one concentration (the size of the read-out at that concentration, not a potency): -23%
Compound 4: the middle estimate sits 13 percentage points above what was measured; low and high end bracket the measured number.
By their numbers in this assay, from the lowest: compound 3; then compound 4; then compounds 1 and 2 (each within the scatter of the next).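

In this assay there is a number 14 percentage points higher from compound 3 to compound 4 (beyond the scatter), so even two fluorophenyl groups on this amine nitrogen in a ring are separated beyond the scatter, although the change swaps 3-fluorophenyl for 2,6-difluorophenyl and so alters both the number and the placement of fluorine at once. Compound 4 also stays clearly apart from the two other groups, with a number 26.2 percentage points lower from compound 1 to compound 4 (beyond the scatter) and a number 36 percentage points lower from compound 2 to compound 4 (beyond the scatter), which places both fluorophenyl compounds, compound 3 and compound 4, at lower numbers than compound 1 and compound 2. No available evidence explains these steps.

Open, from the compounds shown here alone, is whether fluorine number or placement drives the step from compound 3 to compound 4, which a 2-fluorophenyl or 3,5-difluorophenyl group would help separate. Also open, going by these compounds, is how this read-out responds to an amine or a carboxylic acid on the phenyl ring.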